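Thiazole amide series: cytotoxicity after a chloropyridine swap

The source may hold more compounds than are shown below. What is called first, only, known or untested is meant among the compounds shown, and "the series" means these compounds.

Compound 1 `CC(C)(C)OC(=O)Nc1ncc(C(Oc2ccc(OCc3ccccc3)cc2)c2ccc(Cl)cc2)s1`, compound 2 `O=C(Nc1ncc(C(OCc2ccc(Br)cc2)c2ccccc2)s1)c1cccs1` and compound 3 `O=C(Nc1ncc(C(Oc2ccc3cc(Br)ccc3c2)c2ccc(Cl)cc2)s1)C1CCCO1` share a core and were run in an ADME assay on HepG2 2.2.15 cells (Homo sapiens) for cytotoxicity; on this read-out lower numbers stand for higher toxicity in this test and higher numbers for lower toxicity in this test. In this assay compound 1 gives a limit of > 50000 nM rather than a number. Compound 2 is reported in this assay only as "not toxic" (no number reported). Compound 3 likewise gives "not toxic" (no number reported) in this assay, so no single number stands for it. One further value is a limit (the limit of > 50000 nM in this assay, at which 1 of the 3 values shown sits), and one further entry carries no number. Compound 4 `O=C(Nc1ncc(C(Oc2ccc3cc(Br)ccc3c2)c2ccc(Cl)cc2)s1)c1ccc(Cl)nc1` differs from compound 3 by 6-chloropyridin-3-yl in place of oxolan-2-yl on a carbonyl carbon. No step between measured compounds is shown; all entries so far sit at the limit of > 50000 nM in this assay, at which 1 of the 3 values shown sits, or carry no number, and no shift beyond the scatter is expected in this assay for this change. Compound 4 is expected to give 50000 nM in this assay, within 30000 nM to 100000 nM, most likely again reported only as a limit.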

Compound 4, half-maximal cytotoxic concentration: "not toxic" (no number reported)
No number was reported for compound 4; no gap can be computed for the estimate.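

Compound 3 and compound 4 are both reported in this assay only as "not toxic", without a number, so no step can be read between them. What stays open is where either compound's cytotoxic concentration actually lies, as the only entry with a figure is a limit: the limit of > 50000 nM in this assay, at which 1 of the 4 values shown sits.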